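Removing a chloro from the fused ring of compound 3

This account rests on a few compounds, and the source may have more. Where it says the series, first, only, none or still open, it means among the compounds named here.

Measured so far in an assay on HEK293 cells for displacement of a labelled ligand from D(4) dopamine receptor (Homo sapiens); on this read-out lower numbers stand for stronger inhibition and higher numbers for weaker inhibition:
compound 1, `Clc1ccc(CN2CC=C(c3nc4cc(Cl)ccc4[nH]3)CC2)cc1`, gives 10 nM
compound 2, `Clc1ccc2sc(C3=CCN(Cc4ccccc4)CC3)nc2c1`, gives 44 nM
compound 3, `Clc1ccc(CN2CC=C(c3nc4cc(Cl)ccc4s3)CC2)cc1`, gives 21 nM

Compound 3 stands second of the three numbers in this assay: compound 2 lies a step away, a 2.1-fold lower number from compound 2 to compound 3 (0.32 log units; beyond the scatter), and compound 1 lies the same distance in the other direction, as its value shows. The move from compound 3 to compound 4, `Clc1ccc(CN2CC=C(c3nc4ccccc4s3)CC2)cc1`, is hydrogen in place of chloro on an aromatic carbon. Among the compounds with values here, only one measured step involves a chloro, the one from compound 2 to compound 3, and that chloro sits elsewhere in the molecule: adding it brought a modest gain, a 2.1-fold lower number from compound 2 to compound 3 (0.32 log units; beyond the scatter). Within the data shown here, no measured pair shows what the chloro on the fused ring itself contributes, so the bearing of the known step on this change is indirect. Taking the earlier step as the nearest guide, and since it ran toward a lower number when a chloro was added, compound 4 is expected to move the other way by a comparable, modest amount, a 1.9-fold higher number from compound 3 to compound 4 (0.28 log units; within the scatter). Compound 4 is therefore estimated at 40 nM, with a range from 15 nM to 110 nM.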

Compound 4, inhibition constant: 1.3 nM
The estimate for compound 4 lay 31-fold (1.49 log units) above the measured number; the measured number lies below the stated range.
By their numbers in this assay, from the lowest: compound 4; then compound 1; then compound 3; then compound 2.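

In this assay, within the data shown here, the chloro on the fused ring turns out to matter far more than the earlier compounds suggested: at this aromatic carbon, para to a fused ring and meta to a fused ring, hydrogen in place of chloro gives a 16-fold lower number from compound 3 to compound 4 (1.21 log units; beyond the scatter) as a large step. Among these compounds, the only earlier chloro step ran the opposite way and was much smaller, a 2.1-fold lower number from compound 2 to compound 3 (0.32 log units; beyond the scatter) for a chloro added elsewhere in the molecule, so within these compounds a chloro in one place goes with a lower number and a chloro in the other with a higher one, and the first step says nothing about the second. Nothing measured here accounts for the size of this step or for the difference between the two places.

As far as these compounds go, whether any group other than hydrogen at this carbon could match compound 4 stays open, and a fluoro, a methoxy or an amine there would test how closely the low number is tied to the bare hydrogen. From the compounds shown here alone, it also remains unknown whether the same large step would appear in the core of compound 1, which still carries its chloro at the corresponding carbon.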